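The source may hold more compounds than are shown below. What is called first, only, known or untested is meant among the compounds shown, and "the series" means these compounds.

Of the compounds shown here, two on the shared core have so far been measured in a functional assay on HeLa cells (Homo sapiens) for antiproliferative activity, read by XTT assay, with a stated time of 72 h; on this read-out lower numbers stand for stronger inhibition and higher numbers for weaker inhibition. Compound 1 (`C=C(C)CCC[C@]1(C)C2=CCC[C@](C)(C[C@@H](OC(C)=O)C3=CC(=O)OC3O)[C@H]2CC[C@H]1C`) gives 3500 nM on this read-out, and compound 2 (`C=C(C)CC[C@]1(C)C2=CCC[C@](C)(C[C@@H](O)C3=CC(=O)OC3O)[C@H]2CC[C@H]1C`) gives 5400 nM on the same read-out. Going by the values given here, these two values lie within the usual scatter of each other, so compound 2 cannot be ranked ahead of or behind the only other compound measured. Compound 3 (`C=C(C)CC[C@]1(C)C2=CCC[C@](C)(C[C@@H](OC(C)=O)C3=CC(=O)OC3O)[C@H]2CC[C@H]1C`) has not yet been measured. It differs from compound 2 by acetyl in place of hydrogen on an oxygen on a saturated carbon, which is acetyl in place of hydrogen on an oxygen on a saturated carbon, or hydroxy to acetoxy. Among the compounds with values here, no measured pair isolates this change, so the data give no direct size for it. Within the data shown here, with compound 1 at 3500 nM and compound 2 at 5400 nM as the only guides, no step beyond the scatter is expected in this assay, in either direction. The estimated step of a 1.4-fold lower number from compound 2 to compound 3 (0.13 log units; within the scatter) is accordingly expected to remain small. Compound 3 is expected at 4000 nM, with an estimated range from 1800 nM to 9000 nM for the eventual measurement.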

Compound 3, half-maximal inhibitory concentration: 6700 nM
Beside the measured number, compound 3's estimate is 1.7-fold (0.22 log units) below it; the range from low to high includes it.
By their numbers in this assay, from the lowest: compounds 1, 2 and 3 (each within the scatter of the next).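

In this assay, acetyl in place of hydrogen on an oxygen on a saturated carbon now has a measured size: the pair shows a 1.2-fold higher number from compound 2 to compound 3 (0.09 log units; within the scatter) and so, on the shared core, hydroxy and acetoxy at this position cannot be told apart in this assay. Going by these compounds alone, the second pair gives a first reading of a change elsewhere on the molecule, 1-methylethenyl in place of 2-methylprop-2-en-1-yl on a saturated chain carbon, two bonds along the chain from a saturated ring carbon, and shows a 1.9-fold higher number from compound 1 to compound 3 (0.28 log units; within the scatter) so this change cannot be told apart from the scatter either. Nothing in the information available offers an explanation for either result.

As far as these compounds go, each change rests on a single pair, so it remains open whether a different group on that oxygen, such as a benzoyl group or an amine in place of the acetoxy, would give a step beyond the scatter. From the compounds shown here alone, it is equally open whether a longer chain, or a carboxylic acid in place of the 1-methylethenyl group, would separate from these compounds in this assay.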